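From a hexyl chain to a fluorophenyl ring

A few compounds are considered here, and "the series" means these few. Any claim that something is new, unique, unknown or untested is made for them only; others in the source may bear on it.

Compound 3 `CCCCCCOc1ccc(-n2cnnc2CCCCCC)cc1` stands at the far end of its small series. In a functional assay on the whole organism (strain C57B/6) with Mus musculus as the target, in the maximal electroshock model (a lower number here means that less compound is needed, a higher number that more compound is needed for the effect), compound 3 gives > 40 mg/kg, which is a limit of the assay rather than a number (the limit of > 40 mg/kg in this assay, at which 1 of the 3 values shown sits). Its shorter relatives are measured: compound 1 `CCCCCCOc1ccc(-n2cnnc2CC)cc1` gives 13.2 mg/kg and compound 2 `CCCCCCOc1ccc(-n2cnnc2CCC)cc1` gives 5.7 mg/kg in this assay. The steps of a 2.3-fold lower number from compound 1 to compound 2 (0.36 log units; beyond the scatter) and an at least 7.0-fold higher number from compound 2 to compound 3 (0.84 log units; beyond the scatter) show the number dropping with one added methyl and then climbing past the limit as the chain grows to hexyl; an at least 3.0-fold higher number from compound 1 to compound 3 (0.48 log units; beyond the scatter) points the same way. Compound 4 `CCCCCCOc1ccc(-n2cnnc2-c2ccccc2F)cc1` carries 2-fluorophenyl in place of hexyl on an aromatic carbon. Going by the values given here, no measured step swaps a chain for a ring, so the aryl change lies outside the evidence; only the loss of hexyl echoes the measured steps. Compound 4 is therefore expected to come back within the measurable range, with an at least 2.6-fold lower number from compound 3 to compound 4 (0.42 log units; beyond the scatter) as its estimated step. The estimate for compound 4 is 15 mg/kg, within 5 mg/kg to 45 mg/kg.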

Compound 4, dose for half-maximal effect: 20.2 mg/kg
Compound 4: the middle estimate sits 1.3-fold (0.13 log units) below what was measured; the range from low to high includes it.
By their numbers in this assay, from the lowest: compound 2; then compounds 1 and 4 (each within the scatter of the next). At a limit, above all of these: compound 3.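

On the aromatic carbon that carried the alkyl chains, 2-fluorophenyl gives a measurable value in this assay, so this position takes an aromatic ring as well as a chain. Against hexyl, the change can be read only as a floor (an at least 1.9-fold lower number from compound 3 to compound 4 (0.29 log units; that floor lies within the scatter)), and compound 3 remains a limit: the limit of > 40 mg/kg in this assay, at which 1 of the 4 values shown sits. Against the shorter chains, the ring shows a 1.5-fold higher number from compound 1 to compound 4 (0.18 log units; within the scatter) and a 3.5-fold higher number from compound 2 to compound 4 (0.55 log units; beyond the scatter), so only the propyl compound stands clearly apart.

From the compounds shown here alone, what the fluorine contributes stays open; a plain phenyl or 4-fluorophenyl group could address that. Going by these compounds, whether cyclohexyl would follow the chains or the aromatic ring also stays open.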